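Hydroxythiosemicarbazones on Vero cells: chloro to nitro

The source may hold more compounds than are shown below. What is called first, only, known or untested is meant among the compounds shown, and "the series" means these compounds.

Working notes on a small series sharing one core. Compound 1 `C/C(=N\NC(=S)NO)c1ccccc1` is the unsubstituted parent; in an ADME assay on Vero cells (Chlorocebus sabaeus) for cytotoxicity, read by MTT assay, with a stated time of 72 h (a higher number here means a weaker inhibitor, a lower number a stronger inhibitor), compound 1 shows "not determined" (no result reported). Compound 2 `C/C(=N\NC(=S)NO)c1ccc(C)cc1` carries a methyl on the ring. In this assay compound 2 reaches only the limit > 279000 nM. Compound 3 `C/C(=N\NC(=S)NO)c1ccc(Cl)cc1` carries chloro in its place. In this assay compound 3 likewise gives only the limit > 256000 nM. Compound 3 thus stands at a limit, beside one further limit and one entry without a number. The step that the two limits leave unreadable from compound 2 to compound 3 is unreadable from the two limits the limit of > 279000 nM in this assay, at which 1 of the 3 values shown sits, and (the limit of > 256000 nM in this assay, at which 1 of the 3 values shown sits). Compound 4 `C/C(=N\NC(=S)NO)c1ccc([N+](=O)[O-])cc1` differs from compound 3 by nitro in place of chloro on an aromatic carbon. Within the data shown here, no measured step of readable size bears on this change. Compound 4 is expected to stay near the same limit, a step that the limit leaves unreadable from compound 3 to compound 4 in this assay. The estimate for compound 4 is 300000 nM, ranging from 100000 nM to 1000000 nM.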

Compound 4, half-maximal inhibitory concentration: > 245000 nM
Compound 4: only a limit was reported (the forecaster's own chance of this, stated with the estimate: 75%); the middle value lies beyond the limit too.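

Among these compounds, compound 2, compound 3 and compound 4 each stand only at a limit in this assay, so no step among them can be read. From the compounds shown here alone, whether methyl, chloro or nitro shifts the value on the shared core remains open.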